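Replacing the dichlorophenyl tail: a solubility estimate

A few compounds are considered here, and "the series" means these few. Any claim that something is new, unique, unknown or untested is made for them only; others in the source may bear on it.

Values in a physicochemical assay for solubility, with a stated time of 24 h, at pH 4.5; a lower number here means a less soluble compound, a higher number a more soluble compound (each one a limit):
Compound 1 `O=C(NC[C@@H]1[C@H]2CN(C(=O)CCc3cc(Cl)cc(Cl)c3)C[C@@H]12)c1ccc2[nH]c(=O)oc2c1` gives < 1 ug/mL as a limit
Compound 2 `O=C(NC[C@@H]1[C@H]2CN(C(=O)N3CCc4c(Cl)cc(Cl)cc4C3)C[C@@H]12)c1ccc2[nH]c(=O)oc2c1` gives < 1 ug/mL as a limit

Compound 1 stands at the limit of < 1 ug/mL in this assay, at which 2 of the 2 values shown sit, and this is a limit, not a number. Compound 3 `Cc1cc(COC(=O)N2C[C@@H]3[C@@H](CNC(=O)c4ccc5[nH]c(=O)oc5c4)[C@@H]3C2)no1` keeps the core of compound 1 and carries (5-methyl-1,2-oxazol-3-yl)methoxy in place of 2-(3,5-dichlorophenyl)ethyl on a carbonyl carbon. Going by the values given here, no measured step guides the expectation, which rests on this change alone. The expected step is an at least 15-fold higher number from compound 1 to compound 3 (1.17 log units; beyond the scatter) upward in this assay and beyond the scatter. For compound 3 the estimated value is 15 ug/mL with an expected range from 3 ug/mL to 70 ug/mL in this measurement.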

Compound 3, solubility: > 93 ug/mL
Compound 3 ended at the assay's limit; the forecaster's own chance of this, stated with the estimate: 15%; at least 6.2-fold (0.79 log units) between middle value and limit.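

In this assay, placing (5-methyl-1,2-oxazol-3-yl)methoxy on this carbonyl carbon in place of 2-(3,5-dichlorophenyl)ethyl gives an at least 93-fold higher number from compound 1 to compound 3 (1.96 log units; beyond the scatter). The earlier compounds shown here sat together at one limit and showed no movement, whereas this position can clearly shift the read-out. Compound 3 stands at a limit, not a number: the limit of > 93 ug/mL in this assay, at which 1 of the 3 values shown sits.

This single change swaps the whole group, so the share of the chlorines, the aromatic ring and the oxygen link stays unresolved. From the compounds shown here alone, whether a tail carrying an amine or a carboxylic acid would behave alike also remains open.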